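This account rests on a few compounds, and the source may have more. Where it says the series, first, only, none or still open, it means among the compounds named here.

Compound 1 `CCCCCCCCc1ccc(CCC(CO)(CO)NC(=O)CCC)c2ccccc12` gives 26400 nM in a functional assay on HT-29 cells (Homo sapiens) for antiproliferative activity, read by sulforhodamine B assay, with a stated time of 72 h; on this read-out lower numbers stand for stronger inhibition and higher numbers for weaker inhibition. Compound 2 `CCCCCCCCCC(=O)NC(CO)(CO)CCc1ccc(CCCCCCCC)c2ccccc12` carries hexyl in place of hydrogen on a saturated chain carbon, three bonds along the chain from a carbonyl carbon. In this assay compound 2 reaches only the limit > 80000 nM. That change reads an at least 3.0-fold higher number from compound 1 to compound 2 (0.48 log units; beyond the scatter), and the limit involved is the limit of > 80000 nM in this assay, at which 2 of the 3 values shown sit.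

Compound 3 `COc1ccc(CCC(CO)(CO)NC(C)=O)c2ccccc12` sits on a different core; the difference between the cores of compound 3 and compound 1 is not broken down here. In this assay compound 3 gives only the limit > 80000 nM.

Compound 4 `CCCCCCCOc1ccc(CCC(CO)(CO)NC(C)=O)c2ccccc12` is not yet measured. Within the data shown here, it carries hexyl in place of hydrogen on a saturated chain carbon bound to an oxygen on an aromatic ring, the same kind of change as the one from compound 1 to compound 2, but at another place: there the hexyl entered on a saturated chain carbon, three bonds along the chain from a carbonyl carbon, here on a saturated chain carbon bound to an oxygen on an aromatic ring. Since compound 3 already stands at the limit > 80000 nM and the earlier step of an at least 3.0-fold higher number from compound 1 to compound 2 (0.48 log units; beyond the scatter) moved the number higher, compound 4 is expected to give a step of a number no higher from compound 3 to compound 4 (the limit leaves the size open), most likely again a limit. The estimate for compound 4 in this assay is 80000 nM, between 20000 nM and 250000 nM.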

Compound 4, half-maximal inhibitory concentration: 17600 nM
The estimate for compound 4 lay 4.5-fold (0.66 log units) above the measured number, outside the stated range (below it).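

In this assay, hexyl in place of hydrogen on a saturated chain carbon bound to an oxygen on an aromatic ring gives an at least 4.5-fold lower number from compound 3 to compound 4 (0.65 log units; beyond the scatter), so methoxy to heptyloxy goes with a lower number on this core. Set beside the earlier step, the same hexyl change does not keep its direction from one core to the other: the same change on two cores in this assay, an at least 3.0-fold higher number (0.48 log units; beyond the scatter) from compound 1 to compound 2 and an at least 4.5-fold lower number (0.65 log units; beyond the scatter) from compound 3 to compound 4, at least 13-fold (1.13 log units) apart, beyond the scatter of two such steps. This does not fix the true size of either step, nor does it separate the effect of the core from that of the place of the change, since the hexyl entered at a different place in each pair and each step ends on a limit: the limit of > 80000 nM in this assay, at which 2 of the 4 values shown sit.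

Still open, from the compounds shown here alone, is whether a longer chain than heptyloxy on the aromatic ring oxygen, or a shorter one such as butoxy, keeps the lower number. Also open, going by these compounds, is how the core of compound 4 responds when a hydroxymethyl group gives way to an amine or a carboxylic acid.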